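The source may hold more compounds than are shown below. What is called first, only, known or untested is meant among the compounds shown, and "the series" means these compounds.

Measured compounds:
- compound 1, `Cc1ccccc1-c1nnc(N(C)N)s1`: 41 mg/kg
- compound 2, `Cc1ccccc1-c1nnc(N(C)NC2CCCC2)s1`: 81 mg/kg

In a functional assay on the whole organism with Mus musculus as the target, with a stated time of 1 h (on this read-out higher numbers stand for an effect only at larger amounts of compound and lower numbers for an effect already at smaller amounts), compound 1 gives 41 mg/kg, the lower of the two numbers; compound 2 gives 81 mg/kg, and the two lie within the scatter of each other. Compound 3, `Cc1ccccc1-c1nnc(NN(C)C(C)C)s1`, has not been tested. It differs from compound 1 by a group of 6 heavy atoms (4 carbon, 2 nitrogen; no ring) in place of a group of 3 heavy atoms (1 carbon, 2 nitrogen; no ring), on an aromatic carbon. Among the measured compounds shown here, the only measured step that bears on this, a 2.0-fold higher number from compound 1 to compound 2 (0.30 log units; within the scatter), also adds alkyl on an amine nitrogen and stays within the scatter. For compound 3 a step of a 1.3-fold higher number from compound 1 to compound 3 (0.13 log units; within the scatter) is therefore expected, not beyond the scatter, with an estimated value of 55 mg/kg (range 25 mg/kg to 120 mg/kg).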

Compound 3, dose for half-maximal effect: > 100 mg/kg
Compound 3: no number, only a limit; the forecaster's own chance of this, stated with the estimate: 10%; middle value at least 1.8-fold (0.25 log units) away from the limit.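

In this assay, among the compounds shown here, this change on the aromatic carbon gives the first step beyond the scatter: an at least 2.4-fold higher number from compound 1 to compound 3 (0.38 log units; beyond the scatter). The earlier step, a 2.0-fold higher number from compound 1 to compound 2 (0.30 log units; within the scatter), stayed within the scatter, so a larger group at this place does not always leave the number where it was. The reading for compound 3 is a limit and not a number, which leaves the true size of its step unknown: the limit of > 100 mg/kg in this assay, at which 1 of the 3 values shown sits.

Still open, going by these compounds, is whether a short ethyl chain or a carboxylic acid in this group would keep the number close to that of compound 1.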